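Aryl ketone swap on the trimethoxyphenyl pyrazole series

The compounds below may be only part of what the source reports. "The series", "measured", "known", "first", "only" and "open" are said of these compounds alone.

Measured so far:
compound 1, `COc1cc(-c2cc(/C=C/C(=O)c3ccc(N)cc3)[nH]n2)cc(OC)c1OC`, -96%
compound 2, `COc1ccc(-c2cc(/C=C/C(=O)c3ccc(N)cc3)[nH]n2)cc1OC`, -68%
compound 3, `COc1ccc(-c2cc(/C=C/C(=O)c3cc(OC)c(OC)c(OC)c3)[nH]n2)cc1OC`, -97%

In a functional assay on U-251 cells (Homo sapiens) for cytotoxicity, read by sulforhodamine B assay, with a stated time of 48 h, tested at 10 uM (on this read-out higher numbers stand for a weaker effect at the one concentration tested and lower numbers for a stronger effect), compound 1 gives -96%, the second highest of the three numbers; compound 3 sits within the scatter of it, while compound 2 lies beyond the scatter, the step being a number 28 percentage points higher from compound 1 to compound 2 (beyond the scatter).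

Compound 4, `COc1cc(-c2cc(/C=C/C(=O)c3ccc(F)c(F)c3)[nH]n2)cc(OC)c1OC`, is not yet measured. It differs from compound 1 in one place: 3,4-difluorophenyl in place of 4-aminophenyl on a carbonyl carbon. For the measured compounds named here, no measured step touches this ring. Going by the values given here, the only measured step, a number 28 percentage points higher from compound 1 to compound 2 (beyond the scatter), concerns a methoxy group on the other aromatic ring and says nothing about the ketone aryl group. Compound 2 and compound 3 both carry the same core and differ at the ketone aryl ring; compound 2 gives -68% and compound 3 gives -97%, but this pair is not a single counted step here, and neither ring is the difluorophenyl.

Among the compounds with values here, with no direct precedent, compound 4 is expected to stay near compound 1, the expected step being a number 11 percentage points higher from compound 1 to compound 4 (beyond the scatter). The estimate for compound 4 is -85%, between -100% and -50%.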

Compound 4, a percentage reported as activity, at one concentration (the size of the read-out at that concentration, not a potency): 7%
The estimate for compound 4 lay 92 percentage points below the measured number, and the stated range ends below it.
By their numbers in this assay, from the lowest: compounds 3 and 1 (each within the scatter of the next); then compound 2; then compound 4.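

In this assay the aryl group on the carbonyl carbon proves to be a sensitive place on the core of compound 1: with 3,4-difluorophenyl in place of 4-aminophenyl, the result is a number 103 percentage points higher from compound 1 to compound 4 (beyond the scatter) and marks a large step. For the compounds shown here, the earlier step, a number 28 percentage points higher from compound 1 to compound 2 (beyond the scatter), was modest and concerned the other aromatic ring, so this is the first single change read at the ketone aryl group. Nothing available explains the size of this step.

The one swap removes the amino group and brings in two fluorines, so the compounds shown leave open which of these changes accounts for the step. A plain phenyl, a monofluorophenyl or an acetamide-bearing phenyl on the same carbonyl carbon would help separate the two.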